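The compounds below may be only part of what the source reports. "The series", "measured", "known", "first", "only" and "open" are said of these compounds alone.

Measured compounds:
Compound 1, `CN1[C@@H]2c3[nH]c4ccccc4c3C[C@H]1[C@H](C#N)N1[C@@H](CN3C(=O)c4ccccc4C3=O)c3[nH]c4ccccc4c3C[C@@H]21`: 40 nM
Compound 2, `CN1[C@@H]2c3[nH]c4ccccc4c3C[C@H]1[C@H](C#N)N1[C@@H](CNC(=O)c3cccc(C(F)(F)F)c3)c3[nH]c4ccccc4c3C[C@@H]21`: 630 nM

Of the compounds shown here, two built on the same core have been tested in a functional assay on HCT-116 cells (Homo sapiens) for cytotoxicity, read by MTT assay, with a stated time of 72 h; a lower number here means a stronger inhibitor, a higher number a weaker inhibitor. Compound 1 gives 40 nM in this assay, while compound 2 gives 630 nM. Of the two numbers, compound 2 stands at the higher end, and the gap to compound 1 is beyond the usual scatter of this assay.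

Compound 3, `CN1[C@@H]2c3[nH]c4ccccc4c3C[C@H]1[C@H](C#N)N1[C@@H](CNC(=O)c3ccc(Cl)cc3)c3[nH]c4ccccc4c3C[C@@H]21`, has not yet been measured in this assay. It differs from compound 2 in one place: 4-chlorophenyl in place of 3-(trifluoromethyl)phenyl on a carbonyl carbon. Going by the values given here, no measured pair tells how a change of this kind plays out on this core, so the expected step rests on the structural change alone. Because compound 2 gives 630 nM and its amide arrangement is kept while only the aryl group on the carbonyl carbon is exchanged, the step of a 1.3-fold lower number from compound 2 to compound 3 (0.10 log units; within the scatter) is estimated to be small, with no clear direction beyond the scatter. Compound 3 is therefore expected to give about 500 nM in this assay, within a range from 150 nM to 2000 nM.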

Compound 3, half-maximal inhibitory concentration: 630 nM
Beside the measured number, compound 3's estimate is 1.3-fold (0.10 log units) below it, within the range that was stated.
By their numbers in this assay, from the lowest: compound 1; then compounds 2 and 3 (each within the scatter of the next).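

In this assay, the exchange of 3-(trifluoromethyl)phenyl for 4-chlorophenyl on a carbonyl carbon whose other neighbour is an amide-type nitrogen gives no change at the digits printed from compound 2 to compound 3 (within the scatter) and so shows that, for these two aryl groups, the choice makes no difference that this measurement can detect. Replacing the group of compound 1 on the saturated chain carbon bound to a saturated ring carbon gives a 16-fold higher number from compound 1 to compound 3 (1.20 log units; beyond the scatter) and shows that the distance of the amides from compound 1 is not tied to the 3-(trifluoromethyl)phenyl group alone, since it holds for a second aryl amide. Nothing measured here accounts for either of these results.

On these data alone, whether an aryl ring carrying an amine or a carboxylic acid, or a plain methyl group on the carbonyl carbon in place of the aryl ring, would keep an amide in the range of compound 2 and compound 3 remains open. Also open, as far as these compounds go, is whether a succinimide, which keeps the imide of compound 1 but has no benzene ring fused to it, would stay close to compound 1.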